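This account rests on a few compounds, and the source may have more. Where it says the series, first, only, none or still open, it means among the compounds named here.

Compound 1, `Cc1c(C(=O)Nc2ccc(Oc3ccnc4[nH]ccc34)c(F)c2)nnn1-c1ccc(F)c(F)c1`, gives 570 nM in a functional assay on A549 cells (Homo sapiens) for cytotoxicity, read by MTT assay, with a stated time of 72 h; a lower number here means a stronger inhibitor, a higher number a weaker inhibitor. Compound 2, `Cc1c(C(=O)Nc2ccc(Oc3ccnc4[nH]ccc34)cc2)nnn1-c1ccccc1F`, gives 320 nM. Compound 3, `O=C(Nc1ccc(Oc2ccnc3[nH]ccc23)c(F)c1)c1nnn(-c2ccc(F)c(F)c2)c1C(F)(F)F`, gives 350 nM.

Compounds 1 and 3 share a core and differ at one place: trifluoromethyl in place of methyl on an aromatic carbon. That change produces a 1.6-fold lower number from compound 1 to compound 3 (0.21 log units; within the scatter). The three values of compounds 1, 2 and 3 all lie within the scatter of one another, so no order among them can be read. How the core of compound 2 differs from that of compound 1 is not broken down here.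

Compound 4, `O=C(Nc1ccc(Oc2ccnc3[nH]ccc23)cc1)c1nnn(-c2ccccc2F)c1C(F)(F)F`, is not yet measured. It stands to compound 2 as compound 3 stands to compound 1: trifluoromethyl in place of methyl on an aromatic carbon. The two place descriptions are not identical, since in compound 1 the ring atom beside the changed carbon bears a 3,4-difluorophenyl group, while in compound 2 it bears a 2-fluorophenyl group; it is therefore the same kind of change rather than the same change. On the strength of the single earlier case, a 1.6-fold lower number from compound 1 to compound 3 (0.21 log units; within the scatter), compound 4 is expected to show a 1.3-fold lower number from compound 2 to compound 4 (0.11 log units; within the scatter) in this assay. Compound 4 is thus estimated at 250 nM, between 110 nM and 560 nM.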

Compound 4, half-maximal inhibitory concentration: 210 nM
Beside the measured number, compound 4's estimate is 1.2-fold (0.08 log units) above it; measured number inside the range.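

In this assay, trifluoromethyl in place of methyl on the core of compound 2 gives a 1.5-fold lower number from compound 2 to compound 4 (0.18 log units; within the scatter), and the two cases of this change agree: the same change on two cores in this assay, a 1.6-fold lower number (0.21 log units; within the scatter) from compound 1 to compound 3 and a 1.5-fold lower number (0.18 log units; within the scatter) from compound 2 to compound 4, 1.1-fold (0.03 log units) apart, within the scatter of two such steps. The step therefore has the same size, as far as this assay can tell, on the two cores shown. It does not establish a real effect of the change, since each step on its own lies within the scatter, and two cores cannot show how the change would behave on any other core in the series.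

The compounds shown leave open whether a group other than methyl or trifluoromethyl at this aromatic carbon, such as an ethyl group, a nitrile or a carboxylic acid, would give a number beyond the scatter. They also leave open how the same change would behave with a plain phenyl group in place of the 2-fluorophenyl group.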